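The source may report more compounds than this note shows. Statements on the series, on what has been measured and on what is new or still open speak of the compounds shown alone.

Compound 3 `O=C(NCCCCc1ccccc1)c1cccc(C2SCC(=O)N2c2ccccc2)c1` belongs to a set of three related compounds. In a functional assay on HOS cells (Homo sapiens) for inhibition, read by CCK-8 assay, with a stated time of 72 h, tested at 1 uM (a lower number here means less inhibition, a higher number more inhibition at the concentration tested (going by the name of the read-out)), compound 3 gives 55%, the lowest of the three readings: compound 1 `COc1cccc(OC)c1N1C(=O)CSC1c1cccc(C(=O)NCCCCc2ccccc2)c1` gives 80% and compound 2 `COc1cc(F)ccc1N1C(=O)CSC1c1cccc(C(=O)NCCCCc2ccccc2)c1` gives 81%. Compound 4 `COc1ccc(F)cc1N1C(=O)CSC1c1cccc(C(=O)NCCCCc2ccccc2)c1` differs from compound 3 in one place (5-fluoro-2-methoxyphenyl in place of phenyl on an amide-type nitrogen in a ring). Among the measured compounds shown here, two measured steps bear on this change, both running the opposite way, from a larger ring like the one entering here to plain phenyl: a number 25 percentage points lower from compound 1 to compound 3 (beyond the scatter) and a number 26 percentage points lower from compound 2 to compound 3 (beyond the scatter). Between the two larger rings the step of a number 1 percentage points higher from compound 1 to compound 2 (within the scatter) was small. Bringing such a ring back is therefore expected to raise inhibition by a modest step, a number 23 percentage points higher from compound 3 to compound 4 (beyond the scatter). Compound 4 is thus estimated at 78%, with a range from 65% to 88%.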

Compound 4, a percentage reported as inhibition, at one concentration (the size of the read-out at that concentration, not a potency): 46%
Compound 4: middle estimate off by 32 percentage points, on the high side; measured number below the stated range.
By their numbers in this assay, from the lowest: compounds 4 and 3 (each within the scatter of the next); then compounds 1 and 2 (each within the scatter of the next).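

In this assay, moving from 4-fluoro-2-methoxyphenyl to 5-fluoro-2-methoxyphenyl gives a number 35 percentage points lower from compound 2 to compound 4 (beyond the scatter) and so shows that a larger ring at this position is not enough: how its groups are arranged matters. The change from 2,6-dimethoxyphenyl gives a number 34 percentage points lower from compound 1 to compound 4 (beyond the scatter) and points the same way. Compared with plain phenyl, the new ring gives a number 9 percentage points lower from compound 3 to compound 4 (within the scatter) and shows no clear gain. Nothing measured here explains these differences.
Still open, on these data alone, is whether 2-methoxyphenyl, with no fluorine, would read like compound 2 or compound 4, and what a chlorine in the fluorine's place would do.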